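Extending the saturated chain of compound 3

A few compounds are considered here, and "the series" means these few. Any claim that something is new, unique, unknown or untested is made for them only; others in the source may bear on it.

Of the compounds shown here, three sharing one core have been tested in an ADME assay on Vero cells (Chlorocebus sabaeus) for cytotoxicity, read by MTT assay; on this read-out higher numbers stand for weaker inhibition and lower numbers for stronger inhibition. Compound 1 `CCCCCCC(=O)OCC(C)(C)CC1=C(O)C(=O)c2ccccc2C1=O` gives a measured number of 99300 nM. Compound 2 `CCCCCCCC(=O)OCC(C)(C)CC1=C(O)C(=O)c2ccccc2C1=O` returns only a limit of > 258000 nM. Compound 3 `CCCCCCCCCCC(=O)OCC(C)(C)CC1=C(O)C(=O)c2ccccc2C1=O` likewise returns only a limit, > 233000 nM, so its true position on the scale remains unread.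

Compound 4 `CCCCCCCCCCCC(=O)OCC(C)(C)CC1=C(O)C(=O)c2ccccc2C1=O` differs from compound 3 by one change: methyl in place of hydrogen on a saturated chain carbon, ten or more bonds along the chain from a carbonyl carbon. In words, this is methyl in place of hydrogen on a saturated chain carbon, ten or more bonds along the chain from a carbonyl carbon.

Three measured steps of the same kind bear on this change, all of them further down the chain. The series shows an at least 2.5-fold higher number from compound 1 to compound 2 (0.41 log units; beyond the scatter) and also an at least 2.3-fold higher number from compound 1 to compound 3 (0.37 log units; beyond the scatter). Both of these are beyond the scatter, though each ends on a limit. Further out, the data give a step that the two limits leave unreadable from compound 2 to compound 3, so the closest step offers no size to carry forward.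

No step beyond the scatter is therefore expected in this assay, and a report of only a limit is the likely result. The step is estimated as an at least 1.0-fold lower number from compound 3 to compound 4 (0.00 log units; that floor lies within the scatter). Compound 4 is expected near 230000 nM, with an estimated range from 110000 nM to 450000 nM.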

Compound 4, half-maximal inhibitory concentration: 249000 nM
Compound 4: the middle estimate sits 1.1-fold (0.03 log units) below what was measured; low and high end bracket the measured number.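

In this assay, compound 4 carries a number where compound 2 and compound 3 carry only limits, so the rise from the shorter chain of compound 1 now has a readable size: a 2.5-fold higher number from compound 1 to compound 4 (0.40 log units; beyond the scatter). Set against compound 2, the longer chain gives an at least 1.0-fold lower number from compound 2 to compound 4 (0.01 log units; that floor lies within the scatter), which shows no change beyond the scatter. The steps from compound 2 to compound 3 and from compound 3 to compound 4 cannot be read, as limits stand on them, so the methyl at this far position has no size of its own.

On these data alone, how a still longer chain, or a carboxylic acid in place of this methyl, would read in this assay remains open. Also open is whether lengthening the chain counts alike at the two places where it was compared: the same change on two cores in this assay, an at least 2.3-fold higher number (0.37 log units; beyond the scatter) from compound 1 to compound 3 and an at least 1.0-fold lower number (0.01 log units; that floor lies within the scatter) from compound 2 to compound 4; the limit leaves it open whether they differ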